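The source may hold more compounds than are shown below. What is called first, only, known or untested is meant among the compounds shown, and "the series" means these compounds.

Compound 1 `COc1ccccc1C#Cc1cc(Cl)cn2c([N+](=O)[O-])c(CS(=O)(=O)c3ccccc3)nc12`: > 3900 nM
Compound 2 `Nc1ccc(C#Cc2cc(Cl)cn3c([N+](=O)[O-])c(CS(=O)(=O)c4ccccc4)nc23)cc1`: > 3900 nM
Compound 3 `O=[N+]([O-])c1c(CS(=O)(=O)c2ccccc2)nc2c(C#Cc3cccnc3)cc(Cl)cn12`: > 3900 nM
Compound 4 `O=[N+]([O-])c1c(CS(=O)(=O)c2ccccc2)nc2c(C#CCCO)cc(Cl)cn12`: not yet measured

These entries come from an ADME assay on HepG2 cells (Homo sapiens) for cytotoxicity, read by MTT assay, with a stated time of 72 h (on this read-out higher numbers stand for lower toxicity in this test and lower numbers for higher toxicity in this test), and each is a limit, not a number. In this assay compound 3 gives > 3900 nM, which is a limit. Going by the values given here, the series so far shows (the limit of > 3900 nM in this assay, at which 3 of the 3 values shown sit).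

The change to compound 4 is 2-hydroxyethyl in place of pyridin-3-yl on a triple-bonded carbon. Among the compounds with values here, the steps that bear on it changed the same place: a step that the two limits leave unreadable from compound 1 to compound 2, a step that the two limits leave unreadable from compound 1 to compound 3 and a step that the two limits leave unreadable from compound 2 to compound 3. None of them has a readable size, so they give no direction.

The expected step is a step that the limit leaves unreadable from compound 3 to compound 4, a loose estimate that leans towards lower toxicity in this assay only if it proves readable at all.

For compound 4 the estimated value is 8000 nM, with an expected range of 3900 nM to 40000 nM.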

Compound 4, half-maximal cytotoxic concentration: > 125000 nM
Compound 4 gave a limit, no number; the forecaster's own chance of this, stated with the estimate: 85%; middle value at least 15-fold (1.19 log units) from the limit.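

In this assay, going by these compounds alone, compound 1, compound 2, compound 3 and compound 4 all give only limits, so no step to compound 4 can be read. The compounds shown leave open whether replacing the group on the triple-bonded carbon with 2-hydroxyethyl changes the half-maximal cytotoxic concentration at all.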